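Ethylamino Variant of the Shared Core in KB Cells

This account rests on a few compounds, and the source may have more. Where it says the series, first, only, none or still open, it means among the compounds named here.

Of the compounds shown here, three on a shared core have been measured in a functional assay on KB cells (Homo sapiens) for cytotoxicity, read by MTT assay, with a stated time of 72 h; on this read-out higher numbers stand for weaker inhibition and lower numbers for stronger inhibition. Compound 1 `CN(C)c1nc2c(ncn2-c2ccccc2)c(=O)n1-c1ccccc1` gives 83800 nM. Compound 2 `CC(C)N(c1nc2c(ncn2-c2ccccc2)c(=O)n1-c1ccccc1)C(C)C` gives 53500 nM. Compound 3 `CNc1nc2c(ncn2-c2ccccc2)c(=O)n1-c1ccccc1` gives only a limit of the assay, > 100000 nM, which is the limit of > 100000 nM in this assay, at which 1 of the 3 values shown sits. Where compound 3 stands is thus known only as a floor; the steps of an at least 1.1-fold higher number from compound 1 to compound 3 (0.07 log units; that floor lies within the scatter) and an at least 1.8-fold higher number from compound 2 to compound 3 (0.27 log units; that floor lies within the scatter) both carry that floor and both lie within the scatter, as does a 1.6-fold lower number from compound 1 to compound 2 (0.19 log units; within the scatter).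

Compound 4 `CCNc1nc2c(ncn2-c2ccccc2)c(=O)n1-c1ccccc1` differs from compound 3 by methyl in place of hydrogen on a saturated chain carbon bound to a nitrogen on an aromatic ring, that is, methyl to ethyl; methylamino to ethylamino. The measured steps that bear on this change are those that alter the alkyl groups on the same nitrogen, an at least 1.8-fold higher number from compound 2 to compound 3 (0.27 log units; that floor lies within the scatter) and an at least 1.1-fold higher number from compound 1 to compound 3 (0.07 log units; that floor lies within the scatter), and neither reaches beyond the scatter. Nothing in these values points to a shift beyond the scatter in this assay when a methyl is added at this position. The expected step is therefore a number no higher from compound 3 to compound 4 (the limit leaves the size open). Compound 4 is estimated at 100000 nM, between 50000 nM and 200000 nM.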

Compound 4, half-maximal inhibitory concentration: > 100000 nM
Compound 4: only a limit was reported; the forecaster's own chance of this, stated with the estimate: 50%; the middle value lies on the limit itself.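

In this assay compound 4 gives > 100000 nM, a limit and not a number, and compound 3 stands at the same limit: the limit of > 100000 nM in this assay, at which 2 of the 4 values shown sit. The step between these two cannot be read, so the methyl added on the saturated chain carbon has no measurable size here. The remaining steps are an at least 1.8-fold higher number from compound 2 to compound 4 (0.27 log units; that floor lies within the scatter) and an at least 1.1-fold higher number from compound 1 to compound 4 (0.07 log units; that floor lies within the scatter); ethylamino, like methylamino before it, is therefore not separated from diisopropylamino or dimethylamino on this read-out, as both floors lie within the scatter.

On these data alone, whether a longer chain on this nitrogen, such as n-propylamino or n-butylamino, would give a number rather than a limit remains open. So does the effect of a cyclic amine such as morpholine or piperidine in place of these alkylamino groups on the aromatic carbon.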